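A Second Chloro on the Anilino Ring

The source may hold more compounds than are shown below. What is called first, only, known or untested is meant among the compounds shown, and "the series" means these compounds.

Compound 1 `COc1cc(/C=C/C(=O)c2sc(Nc3ccc(Cl)cc3)nc2C)cc(OC)c1OC`: > 25000 nM, a limit of the assay.
Compound 2 `COc1cc(/C=C/C(=O)c2sc(Nc3cccc(Cl)c3)nc2C)cc(OC)c1OC`: 11600 nM.

For the measured compounds named here, in a functional assay on BGC-823 cells (Homo sapiens) for cytotoxicity, read by MTT assay (a higher number here means a weaker inhibitor, a lower number a stronger inhibitor), compound 2 is the only compound with a number. In this assay compound 1 gives only > 25000 nM, which is a limit. Going by the values given here, the one measured step, an at least 2.1-fold lower number from compound 1 to compound 2 (0.33 log units; beyond the scatter), is at least modest and bears only on (the limit of > 25000 nM in this assay, at which 1 of the 2 values shown sits).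

Compound 3 `COc1cc(/C=C/C(=O)c2sc(Nc3ccc(Cl)c(Cl)c3)nc2C)cc(OC)c1OC` keeps the 3-chlorophenyl of compound 2 and adds a chloro, (chloro in place of hydrogen on an aromatic carbon). Among the compounds with values here, no measured step adds a group; the one step moves one. The comparison of compound 1 and compound 2 suggests a chloro in this position does not help, yet the 3-chloro is kept here, so little change is expected: a 1.2-fold lower number from compound 2 to compound 3 (0.06 log units; within the scatter). Compound 3 is therefore estimated at 10000 nM, between 4000 nM and 30000 nM.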

Compound 3, half-maximal inhibitory concentration: > 25000 nM
Compound 3: no number, only a limit; the forecaster's own chance of this, stated with the estimate: 20%; middle value at least 2.5-fold (0.39 log units) from the limit.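

With the 3-chloro kept, the added chloro, ortho to a chloro group and para to a large group, gives an at least 2.1-fold higher number from compound 2 to compound 3 (0.33 log units; beyond the scatter) in this assay. So the activity of compound 2 does not survive a second chloro at this place, and the 3,4-dichlorophenyl ring loses what the move of the chloro had gained. Compound 3 gives > 25000 nM, which is a limit of the assay, so the full size of the loss is unknown, and the step between compound 1 and compound 3 cannot be read: the limit of > 25000 nM in this assay, at which 2 of the 3 values shown sit.

On these data alone, it remains open whether a fluoro or a methoxy at this same place on the 3-chlorophenyl ring would keep the activity of compound 2. The same question stands for an amine or a carboxylic acid there.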